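The compounds below may be only part of what the source reports. "The series", "measured", "known", "first", "only" and "open" are said of these compounds alone.

Working notes on this series, read in a physicochemical assay for lipophilicity, using the shake flask method, in phosphate buffer, measured as octanol-water partition, with a stated time of 24 h, at pH 7.4, tested at 100 uM; on this read-out lower numbers stand for lower lipophilicity and higher numbers for higher lipophilicity. Compound 1 (`Cc1cc(OCC(C)C)cc(C)c1-c1cccc(COc2ccc(OCC(=O)O)c(F)c2)c1`) offers no number, its entry being "not determined" (no result reported). Compound 2 (`Cc1cc(OCCCS(C)(=O)=O)cc(C)c1-c1cccc(COc2ccc(OCC(=O)O)c(F)c2)c1`) gives 1.81, the only measured point so far, so it cannot yet be ranked against anything.

Compound 3 (`Cc1cc(OCCCO)cc(C)c1-c1cccc(COc2ccc(OCC(=O)O)c(F)c2)c1`) departs from compound 2 at one place: hydroxy in place of methylsulfonyl on a saturated chain carbon, three bonds along the chain from an oxygen on an aromatic ring. This puts hydroxy in place of methylsulfonyl on a saturated chain carbon, three bonds along the chain from an oxygen on an aromatic ring. Among the measured compounds shown here, no measured pair shows this change, so the expectation rests only on the structural change and on compound 2 at 1.81. A modest upward move is expected, a little beyond the scatter, with an estimated step of a number 0.39 log units higher from compound 2 to compound 3 (beyond the scatter). For compound 3 the estimated value is 2.2, with an expected range from 1.8 to 2.6.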

Compound 3, distribution coefficient: 2.73
Compound 3: middle estimate off by 0.53 log units, on the low side; the measured number lies above the stated range.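

In this assay, the change from 3-(methylsulfonyl)propyl to 3-hydroxypropyl gives the series its first readable step, a number 0.92 log units higher from compound 2 to compound 3 (beyond the scatter) and thus the first sign that the read-out responds to what stands at this end of the chain. The replacement of methylsulfonyl by hydroxy on a saturated chain carbon, three bonds along the chain from an oxygen on an aromatic ring, is therefore not a silent change on this core. This remains a single pair, so it sets no trend beyond compound 2 and compound 3.

Still open, going by these compounds, is where an amine, a carboxylic acid or a longer chain ending in hydroxy would fall relative to compound 2 and compound 3 at this position. Nothing available here bears on why the step has this size.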